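Compound 4: Replacing the Phenyl Group of Compound 1

The compounds below may be only part of what the source reports. "The series", "measured", "known", "first", "only" and "open" are said of these compounds alone.

Measured compounds:
compound 1 `Cc1cc(CC(C)C(=O)N2CCN(c3ccc(C(F)(F)F)cc3[C@@H](N)CC(C)C)CC2)ccc1Cl`: 71 nM
compound 2 `CC(C)C[C@H](N)c1cc(C(F)(F)F)ccc1N1CCN(C(=O)COc2cccc3ccccc23)CC1`: 2600 nM
compound 3 `CC(C)C[C@H](N)c1ccccc1N1CCN(C(=O)[C@H](C)Cc2ccc(Cl)cc2F)CC1`: 67 nM

In an assay on HEK293 cells for displacement of a labelled ligand from Melanocortin receptor 4 (Homo sapiens) (on this read-out lower numbers stand for stronger inhibition and higher numbers for weaker inhibition), compound 1 gives the second highest of the three numbers. Its nearest neighbour is compound 3, whose number lies within the scatter of that of compound 1; the furthest is compound 2, whose number stands far higher. Compound 4 `COc1ccc(CC(C)C(=O)N2CCN(c3ccc(C(F)(F)F)cc3[C@@H](N)CC(C)C)CC2)cc1F` has not been measured. It differs from compound 1 by 3-fluoro-4-methoxyphenyl in place of 4-chloro-3-methylphenyl on a saturated chain carbon, two bonds along the chain from a carbonyl carbon.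

Within the data shown here, only one step on the carbonyl side of the shared core has been measured: a 37-fold higher number from compound 1 to compound 2 (1.56 log units; beyond the scatter). That change, however, replaced the whole 1-(4-chloro-3-methylbenzyl)ethyl group, whereas compound 4 keeps that chain and alters only the phenyl substituents. Among the measured compounds shown here, no measured pair isolates such a swap. Compound 4 is therefore expected to stay near compound 1, with a 1.5-fold higher number from compound 1 to compound 4 (0.19 log units; within the scatter) as the estimated step, giving an expected value of 110 nM (range 35 nM to 350 nM).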

Compound 4, inhibition constant: 200 nM
Estimate against measurement, compound 4: 1.8-fold (0.26 log units) below, within the range that was stated.
By their numbers in this assay, from the lowest: compounds 3 and 1 (each within the scatter of the next); then compound 4; then compound 2.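

In this assay, the substituents on the phenyl group matter on their own, with the 1-(4-chloro-3-methylbenzyl)ethyl chain otherwise kept: the swap to 3-fluoro-4-methoxyphenyl gives a 2.8-fold higher number from compound 1 to compound 4 (0.45 log units; beyond the scatter). This step is much smaller than the one that comes with ((naphthalen-1-yl)oxy)methyl, as the 1-(3-fluoro-4-methoxybenzyl)ethyl group still gives a 13-fold lower number from compound 2 to compound 4 (1.11 log units; beyond the scatter). No evidence at hand bears on what lies behind this result. The compounds shown leave open whether the fluoro or the methoxy group carries the step, and how a nitrile or a hydroxyl on the phenyl ring would read at this place.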